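The compounds below may be only part of what the source reports. "The series", "measured", "known", "first", "only" and "open" are said of these compounds alone.

Measured so far:
compound 1, `CCCC/C=C\c1cn([C@H]2C[C@H](O)[C@@H](CO)O2)c(=O)[nH]c1=O`, 361 ug/mL
compound 2, `CC#CCc1cn([C@H]2C[C@H](O)[C@@H](CO)O2)c(=O)[nH]c1=O`, > 1000 ug/mL
compound 3, `CC#Cc1cn([C@H]2C[C@H](O)[C@@H](CO)O2)c(=O)[nH]c1=O`, 164 ug/mL

In a functional assay on L1210 cells (Mus musculus) (a higher number here means a weaker inhibitor, a lower number a stronger inhibitor), compound 3 gives the lowest of the two numbers, with compound 1 nearest at a 2.2-fold lower number from compound 1 to compound 3 (0.34 log units; beyond the scatter). Compound 2 gives no number but only a limit, (the limit of > 1000 ug/mL in this assay, at which 1 of the 3 values shown sits).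

Compound 4, `CCCCCCc1cn([C@H]2C[C@H](O)[C@@H](CO)O2)c(=O)[nH]c1=O`, differs from compound 3 in one place: hexyl in place of prop-1-yn-1-yl on an aromatic carbon. Hexyl is a chain of six carbons, like the hex-1-en-1-yl of compound 1, and the step of a 2.2-fold lower number from compound 1 to compound 3 (0.34 log units; beyond the scatter) showed that shortening to prop-1-yn-1-yl lowered the number. Lengthening again is therefore expected to raise the number, about back to where compound 1 stands. For compound 4 the expected step is a 2.1-fold higher number from compound 3 to compound 4 (0.33 log units; beyond the scatter). Compound 4 is estimated at 350 ug/mL, between 150 ug/mL and 900 ug/mL.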

Compound 4, concentration for 50% inhibition: 301 ug/mL
Compound 4: middle estimate off by 1.2-fold (0.07 log units), on the high side; low and high end bracket the measured number.
By their numbers in this assay, from the lowest: compounds 3, 4 and 1 (each within the scatter of the next, the first and the last beyond it). At a limit, above all of these: compound 2.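

In this assay, hexyl and prop-1-yn-1-yl cannot be told apart at this position: a 1.8-fold higher number from compound 3 to compound 4 (0.26 log units; within the scatter). Replacing hex-1-en-1-yl with hexyl, which removes the chain's double bond, also gives no readable change: a 1.2-fold lower number from compound 1 to compound 4 (0.08 log units; within the scatter). The remaining step, an at least 3.3-fold lower number from compound 2 to compound 4 (0.52 log units; beyond the scatter), is only a bound set by a limit: the limit of > 1000 ug/mL in this assay, at which 1 of the 4 values shown sits.

Going by these compounds, it remains open whether a chain longer than hexyl would follow the same flat pattern. On these data alone, it is also open whether an amine or a carboxylic acid on the chain would move the number beyond the scatter.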